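The source may hold more compounds than are shown below. What is called first, only, known or untested is meant among the compounds shown, and "the series" means these compounds.

Working notes on the series. Compound 1 `CN1CCN(Cc2nnc(-c3cc(S(N)(=O)=O)c(SCc4ccccc4)cc3Cl)o2)CC1` gives 75000 nM in a functional assay on HCT-116 cells (Homo sapiens) for cytotoxicity, read by MTT assay, with a stated time of 72 h (a lower number here means a stronger inhibitor, a higher number a weaker inhibitor), the highest of the two numbers recorded so far. Compound 2 `NS(=O)(=O)c1cc(-c2nnc(CN3CCN(c4ccc(F)cc4)CC3)o2)c(Cl)cc1SCc1ccccc1` gives 34000 nM in this assay; the step of a 2.2-fold lower number from compound 1 to compound 2 (0.34 log units; beyond the scatter) covers 4-fluorophenyl in place of methyl on an amine nitrogen in a ring.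

Compound 3 `CCOC(=O)c1cn(Cc2nnc(-c3cc(S(N)(=O)=O)c(SCc4ccccc4)cc3Cl)o2)nn1` is not yet measured. Relative to compound 1 the change is 4-(ethoxycarbonyl)-1H-1,2,3-triazol-1-yl in place of 4-methylpiperazin-1-yl on a saturated chain carbon bound to an aromatic carbon, so the 4-methylpiperazin-1-yl group is removed altogether rather than decorated. For the measured compounds named here, the single measured step touches only the substituent on that amine nitrogen and so bears on this change only loosely; no step shows what follows when the group itself is replaced. The expectation is therefore a step of modest size at most, in either direction, with the number for compound 3 estimated at 50000 nM (range 12000 nM to 200000 nM), an expected step of a 1.5-fold lower number from compound 1 to compound 3 (0.18 log units; within the scatter).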

Compound 3, half-maximal inhibitory concentration: 108000 nM
Beside the measured number, compound 3's estimate is 2.2-fold (0.33 log units) below it; low and high end bracket the measured number.
By their numbers in this assay, from the lowest: compound 2; then compounds 1 and 3 (each within the scatter of the next).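

Replacing the 4-methylpiperazin-1-yl group outright with 4-(ethoxycarbonyl)-1H-1,2,3-triazol-1-yl, on a saturated chain carbon bound to an aromatic carbon, gives a 1.4-fold higher number from compound 1 to compound 3 (0.16 log units; within the scatter) in this assay. The earlier step changed only the substituent on the amine nitrogen, whereas this one shows that a six-membered non-aromatic ring with 2 hetero atoms and a five-membered aromatic ring with 3 hetero atoms are not separated at this position in this assay, although the two groups share little beyond their place. No other measurement available here bears on this result.

The compounds shown leave open whether a carboxylic acid or a primary amide in place of the ethoxycarbonyl group would give a number apart from those of compound 1 and compound 3. Also open, going by these compounds, is whether a morpholin-4-yl group, or a longer chain between the ring and the shared core, would shift the number at this position.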